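Ester to amide on a glutamate-like side chain

This account rests on a few compounds, and the source may have more. Where it says the series, first, only, none or still open, it means among the compounds named here.

Among the compounds with values here, compound 2 `O=C(CN(c1nc(Cl)nc2[nH]cnc12)C1CC1)N[C@@H](CCC(=O)OCc1ccccc1)C(=O)OCc1ccccc1` gives the higher of the two numbers so far in a functional assay on the whole organism (Tail, strain ICR) with Mus musculus as the target, in the tail flick test, with a stated time of 150 min, at a dose of 25 umol/kg by the oral route (on this read-out higher numbers stand for a stronger effect at the one dose given and lower numbers for a weaker effect), at 44.5%, while compound 1 `C[C@H](NC(=O)CN(c1nc(Cl)nc2[nH]cnc12)C1CC1)C(=O)OCc1ccccc1` gives 23%. Within the data shown here, the only measured step, a number 21.5 percentage points higher from compound 1 to compound 2 (beyond the scatter), came from adding the (benzyloxycarbonyl)methyl group. Compound 3 `NC(=O)CC[C@H](NC(=O)CN(c1nc(Cl)nc2[nH]cnc12)C1CC1)C(=O)OCc1ccccc1` keeps that chain but changes its end: amino in place of benzyloxy on a carbonyl carbon. Among the measured compounds shown here, no measured step speaks to this change, so the expectation rests on the side chain being kept and is wide. The estimated step is a number 8.5 percentage points lower from compound 2 to compound 3 (within the scatter), a value near the scatter. Compound 3 is expected to give 36% in this assay, between 15% and 55%.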

Compound 3, a percentage reported as activity, at one dose (the size of the read-out at that dose, not a potency): 31.1%
Beside the measured number, compound 3's estimate is 4.9 percentage points above it, within the range that was stated.
By their numbers in this assay, from the lowest: compounds 1 and 3 (each within the scatter of the next); then compound 2.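

In this assay, the end of the side chain counts as well as its presence: amino in place of benzyloxy on a carbonyl carbon gives a number 13.4 percentage points lower from compound 2 to compound 3 (beyond the scatter). With carbamoylmethyl in place of hydrogen, the result is a number 8.1 percentage points higher from compound 1 to compound 3 (within the scatter), so this chain, ending in carbamoyl, does not separate itself from hydrogen at this position. Nothing measured here explains the difference between the two chain ends.

From the compounds shown here alone, it remains open whether a carboxylic acid or a methyl ester at the chain end would match compound 2. Going by these compounds, the effect of a longer chain also remains open.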